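The source may hold more compounds than are shown below. What is called first, only, known or untested is meant among the compounds shown, and "the series" means these compounds.

The shared core of compound 1 `CN(C)CCn1c(N)c(-c2nc3ccccc3[nH]2)c2nc(C#N)c(C#N)nc21`, compound 2 `CCN(CC)CCn1c(N)c(-c2nc3ccccc3[nH]2)c2nc(C#N)c(C#N)nc21` and compound 3 `N#Cc1nc2c(-c3nc4ccccc4[nH]3)c(N)n(CCN3CCCC3)c2nc1C#N` carries three different amines on the saturated chain carbon two bonds along the chain from an aromatic nitrogen. In a functional assay on cells (Homo sapiens) for antiproliferative activity, read by MTT assay, with a stated time of 48 h (a lower number here means a stronger inhibitor, a higher number a weaker inhibitor), compound 1 gives 43500 nM. Compound 2 gives 25400 nM, the step being a 1.7-fold lower number from compound 1 to compound 2 (0.23 log units; within the scatter). For compound 3 the assay reports a limit, > 50000 nM, which is the limit of > 50000 nM in this assay, at which 1 of the 3 values shown sits. The steps of an at least 1.1-fold higher number from compound 1 to compound 3 (0.06 log units; that floor lies within the scatter) and an at least 1.9-fold higher number from compound 2 to compound 3 (0.29 log units; that floor lies within the scatter) reach only to that limit. Compound 2 thus stands at one of two numbers, within the scatter of compound 1, the third value being a limit.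

Compound 4 `CCN(CC)CCn1c(N)c(-c2nc3cc(Cl)ccc3[nH]2)c2nc(C#N)c(C#N)nc21` differs from compound 2 in a single place: chloro in place of hydrogen on an aromatic carbon. Within the data shown here, no measured step touches this aromatic carbon; all three concern the amine on the chain. Among the measured compounds shown here, no measured step therefore bears on the change, and no shift beyond the scatter is expected, a 1.0-fold lower number from compound 2 to compound 4 (0.01 log units; within the scatter). Compound 4 is estimated at 25000 nM, with a range from 10000 nM to 55000 nM.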

Compound 4, half-maximal inhibitory concentration: > 50000 nM
Compound 4 ended at the assay's limit; the forecaster's own chance of this, stated with the estimate: 20%; middle value at least 2.0-fold (0.30 log units) from the limit.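

Among these compounds, the change from 1H-benzimidazol-2-yl to 5-chloro-1H-benzimidazol-2-yl is the first step away from the amine on the chain, and in this assay it reads as an at least 1.9-fold higher number from compound 2 to compound 4 (0.29 log units; that floor lies within the scatter). The result for compound 4 is a limit, so this step gives only a floor: chloro on this aromatic carbon brings no gain in the reading, but a loss beyond the scatter cannot be claimed. Only compound 1 and compound 2 now carry actual numbers, which leaves little room for comparison: the limit of > 50000 nM in this assay, at which 2 of the 4 values shown sit.

Open, on these data alone, is whether fluoro or methoxy on this aromatic carbon would give a number inside the range of the assay. Also open, as far as these compounds go, is whether chloro here reads the same with dimethylamino or pyrrolidin-1-yl on the chain.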